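A nitrophenyl swap on the sulfonyl sulfur

A few compounds are considered here, and "the series" means these few. Any claim that something is new, unique, unknown or untested is made for them only; others in the source may bear on it.

Measured in a functional assay on MCF7 cells (Homo sapiens) for antiproliferative activity, read by MTT assay, with a stated time of 48 h; on this read-out lower numbers stand for stronger inhibition and higher numbers for weaker inhibition
Compound 1 `O=C(/C=C/c1cn(S(=O)(=O)c2ccc([N+](=O)[O-])cc2)c2ccccc12)c1ccncc1` gives 14500 nM; "dose-dependent effect" (no number reported) (2 entries)
Compound 2 `COc1ccc(S(=O)(=O)n2cc(/C=C/C(=O)c3ccncc3)c3ccccc32)cc1` gives 65800 nM
Compound 3 `O=C(/C=C/c1cn(S(=O)(=O)c2cccc3ccccc23)c2ccccc12)c1ccncc1` gives 58000 nM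

Compound 3 (58000 nM) and compound 2 (65800 nM) lie within the scatter of each other, so compound 3 stands level with compound 2. Within the data shown here, the single number for compound 1 is lower than the number for compound 3, and the record of compound 1 also holds an entry without a number (the several entries of compound 1 in this assay, 14500 nM; "dose-dependent effect" (no number reported) (2 entries)).

The next compound is compound 4 `O=C(/C=C/c1cn(S(=O)(=O)c2ccccc2[N+](=O)[O-])c2ccccc12)c1ccncc1`, which has 2-nitrophenyl in place of naphthalen-1-yl on a sulfonyl sulfur. Among the measured compounds shown here, only one measured step changes the group at this place, and it stays within the scatter (a 1.1-fold lower number from compound 2 to compound 3 (0.05 log units; within the scatter)). That step alone gives no reason to expect a large move. However, compound 1 (14500 nM; "dose-dependent effect" (no number reported) (2 entries)) also carries a nitrophenyl on the sulfonyl sulfur, so a moderate shift towards a lower number is expected, though this rests on that one compound. The expected change is a 1.9-fold lower number from compound 3 to compound 4 (0.29 log units; within the scatter) in this assay and remains an uncertain estimate. Compound 4 is therefore estimated at 30000 nM (expected range 10000 nM to 75000 nM).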

Compound 4, half-maximal inhibitory concentration: 36900 nM
Compound 4: the middle estimate sits 1.2-fold (0.09 log units) below what was measured, and the stated range covers the measured number.
By their numbers in this assay, from the lowest: compounds 4, 3 and 2 (each within the scatter of the next).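

In this assay, 2-nitrophenyl in place of naphthalen-1-yl on the sulfonyl sulfur gives a 1.6-fold lower number from compound 3 to compound 4 (0.20 log units; within the scatter), and 2-nitrophenyl in place of 4-methoxyphenyl gives a 1.8-fold lower number from compound 2 to compound 4 (0.25 log units; within the scatter). The position has thus taken a third group, one with a nitro substituent and two hydrogen-bond acceptors where naphthalen-1-yl has none, and compound 2, compound 3 and compound 4 still stand level. Compound 4 shares a nitrophenyl group on this sulfur with compound 1, yet its number does not reach the single number in the record of compound 1, a record that also holds an entry without a number: the several entries of compound 1 in this assay, 14500 nM; "dose-dependent effect" (no number reported) (2 entries)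

The compounds shown leave open whether any group at this place can move the number beyond the scatter, since every step read here among compound 2, compound 3 and compound 4 stays within it. A small methyl group on the sulfonyl sulfur, or a phenyl ring carrying an amine or a carboxylic acid, would extend the comparison to groups quite unlike the aromatic ones seen so far.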